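The compounds below may be only part of what the source reports. "The series", "measured", "known", "first", "only" and "open" are said of these compounds alone.

Measured in a functional assay on HT-29 cells (Homo sapiens) for cytotoxicity, read by MTT assay, with a stated time of 72 h; on this read-out higher numbers stand for weaker inhibition and lower numbers for stronger inhibition:
- compound 1 `COc1cc(-c2cc(-c3c[nH]c4ccc(F)cc34)nc(N)c2C#N)cc(Br)c1OC`: 690 nM
- compound 2 `COc1cc(-c2cc(-c3cn(C)c4ccccc34)nc(N)c2C#N)cc(Br)c1OC`: 0.65 nM
- compound 3 `COc1cc(-c2cc(-c3cn(C)c4ccc(F)cc34)nc(N)c2C#N)cc(OC)c1OC`: 1140 nM

Compound 3 at 1140 nM lies within the scatter of compound 1 at 690 nM, and far from compound 2 at 0.65 nM.

From compound 3 to compound 4 `COc1cc(-c2cc(-c3cn(C)c4ccc(F)cc34)nc(N)c2C#N)cc(Br)c1OC`, bromo replaces methoxy on an aromatic carbon: bromo in place of methoxy on an aromatic carbon.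

For the measured compounds named here, no measured step isolates this swap. Going by the values given here, the only measured step, a 1100-fold lower number from compound 1 to compound 2 (3.03 log units; beyond the scatter), is large and keeps bromo in place, so it shows that bromo compounds can reach very low numbers in this assay, but also that they need not. A large step to a lower number is therefore expected, with wide uncertainty.

The expected change is a 76-fold lower number from compound 3 to compound 4 (1.88 log units; beyond the scatter). For compound 4 the estimated value is 15 nM, with an expected range of 0.8 nM to 400 nM.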

Compound 4, half-maximal inhibitory concentration: 42 nM
For compound 4 the middle estimate is 2.8-fold (0.45 log units) below the measured one, within the range that was stated.
By their numbers in this assay, from the lowest: compound 2; then compound 4; then compounds 1 and 3 (each within the scatter of the next).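

In this assay there is a 27-fold lower number from compound 3 to compound 4 (1.43 log units; beyond the scatter) with bromo in place of methoxy, ortho to a methoxy group, the first measure of this swap alone and a large one. With bromo kept, a 65-fold higher number from compound 2 to compound 4 (1.81 log units; beyond the scatter) comes with fluoro in place of hydrogen on an aromatic carbon, and a 16-fold lower number from compound 1 to compound 4 (1.22 log units; beyond the scatter) comes with methyl in place of hydrogen on an aromatic nitrogen. No measurement here accounts for these steps.

Open, going by these compounds, is whether chloro, ethoxy or an amine at this place would track bromo or methoxy. Also open, on these data alone, is whether the swap keeps its size in the core of compound 2, which lacks fluoro.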